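The compounds below may be only part of what the source reports. "The series", "measured", "known", "first", "only" and "open" are said of these compounds alone.

Measured so far:
- compound 2, `COCCNC(=O)[C@@H]1CC[C@@H](Nc2ncc3c(Br)nn(-c4ccc5ncccc5c4)c3n2)C1`: 20 nM
- compound 3, `COCCC(=O)N[C@@H]1CC[C@@H](Nc2ncc3c(Br)nn(-c4ccc5ncccc5c4)c3n2)C1`: 159 nM
- compound 1, `COCCNC(=O)CNc1ncc2c(Br)nn(-c3ccc4ncccc4c3)c2n1`: "nd" (no result reported)

The series shares one core and varies the group on the five-membered non-aromatic ring of carbon only. In an assay on SK-OV-3 cells for inhibition of eIF-2-alpha kinase GCN2 (Homo sapiens) (on this read-out lower numbers stand for stronger inhibition and higher numbers for weaker inhibition), compound 2 gives 20 nM and compound 3 gives 159 nM. Within the data shown here, compound 3 thus stands highest of the two numbers; the only step that reaches it is an 8.0-fold higher number from compound 2 to compound 3 (0.90 log units; beyond the scatter), which turns the (2-methoxyethyl)carbamoyl of compound 2 into the ((2-methoxyethyl)carbonyl)amino of compound 3.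

Compound 4, `CNS(=O)(=O)[C@@H]1CC[C@@H](Nc2ncc3c(Br)nn(-c4ccc5ncccc5c4)c3n2)C1`, is not yet measured. It differs from compound 3 as follows: methylsulfamoyl in place of ((2-methoxyethyl)carbonyl)amino on a saturated ring carbon. Among the measured compounds shown here, the only measured step touching this position is the one from compound 2 to compound 3, and it swaps the two ends of an amide rather than bringing in a sulfamoyl, so it bears on the new step only in that compound 4 again carries a group attached to the ring carbon through a non-nitrogen atom, as compound 2 does. For the measured compounds named here, no measured pair shows a sulfamoyl anywhere, so the direction rests on that likeness alone. The expected step is a 3.2-fold lower number from compound 3 to compound 4 (0.50 log units; beyond the scatter), a lower number, with wide uncertainty. For compound 4 the estimate in this assay is 50 nM, within 15 nM to 180 nM.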

Compound 4, half-maximal inhibitory concentration: 106 nM
For compound 4 the middle estimate is 2.1-fold (0.33 log units) below the measured one; low and high end bracket the measured number.
By their numbers in this assay, from the lowest: compound 2; then compounds 4 and 3 (each within the scatter of the next).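

The new result shows that at this place on the five-membered non-aromatic ring, methylsulfamoyl and ((2-methoxyethyl)carbonyl)amino cannot be told apart in this assay, with a 1.5-fold lower number from compound 3 to compound 4 (0.18 log units; within the scatter). A group joined to the ring carbon through an atom other than nitrogen therefore does not by itself go with the lower number, since the other measured step gives a 5.3-fold higher number from compound 2 to compound 4 (0.72 log units; beyond the scatter), and among the three compounds with numbers only (2-methoxyethyl)carbamoyl stands apart, with its steps to both others beyond the scatter. Nothing measured in this series gives a reason for that difference.

Still open, going by these compounds, is whether the lower number of compound 2 goes with the carbamoyl link or with the 2-methoxyethyl chain, which a methylcarbamoyl or a (2-methoxyethyl)sulfamoyl group at this place would separate. Also open, on these data alone, is what the ring itself contributes, as compound 1 gives "nd" (no result reported) and so offers no comparison, and how an amine or a carboxylic acid at this place would read.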